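Pyridinyl Regioisomers on Two Related Tricyclic Cores

The compounds below may be only part of what the source reports. "The series", "measured", "known", "first", "only" and "open" are said of these compounds alone.

Compound 1 `COC1=CC(=O)c2c(c(COc3cccnc3)c(C)n2C)C1=O` and compound 2 `COC1=CC(=O)c2c(c(COc3ccncc3)c(C)n2C)C1=O` share one core and differ only by pyridin-4-yl in place of pyridin-3-yl on an oxygen on a saturated carbon. In a functional assay on MIA PaCa-2 cells (Homo sapiens) for cytotoxicity, read by MTT assay, with a stated time of 4 h (on this read-out lower numbers stand for stronger inhibition and higher numbers for weaker inhibition), compound 1 gives 904 nM, while compound 2 gives 2010 nM, so that the change produced a 2.2-fold higher number from compound 1 to compound 2 (0.35 log units; beyond the scatter). Compound 3 `COC1=CC(=O)c2c(COc3cccnc3)c(C)n(C)c2C1=O` carries the same pyridin-3-yl group on a core related to that of compound 1, but the difference between the two cores is not broken down here. In this assay compound 3 gives 2480 nM, the highest of the three numbers recorded, though its gap to compound 2 lies within the usual scatter. Compound 4 `COC1=CC(=O)c2c(COc3ccncc3)c(C)n(C)c2C1=O` has not yet been measured. It differs from compound 3 by pyridin-4-yl in place of pyridin-3-yl on an oxygen on a saturated carbon, the same change that separates compound 1 from compound 2, made at the same place. The step is expected to resemble the earlier one, with an estimated 2.2-fold higher number from compound 3 to compound 4 (0.34 log units; beyond the scatter), because the same change gave a 2.2-fold higher number from compound 1 to compound 2 (0.35 log units; beyond the scatter). Compound 4 is therefore estimated at 5400 nM in this assay, with an expected range from 2600 nM to 11000 nM.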

Compound 4, half-maximal inhibitory concentration: 2560 nM
Compound 4: middle estimate off by 2.1-fold (0.32 log units), on the high side, and the stated range ends above it.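

In this assay, putting pyridin-4-yl in place of pyridin-3-yl on the core of compound 3 gives a 1.0-fold higher number from compound 3 to compound 4 (0.01 log units; within the scatter), so the step seen on the core of compound 1 does not reappear there as a step beyond the scatter. Even so, the two steps cannot be told apart as different from each other: the same change on two cores in this assay, a 2.2-fold higher number (0.35 log units; beyond the scatter) from compound 1 to compound 2 and a 1.0-fold higher number (0.01 log units; within the scatter) from compound 3 to compound 4, 2.2-fold (0.33 log units) apart, within the scatter of two such steps. Within the data shown here, this shows that the series gives no firm evidence that the core alters the effect of this change, but it does not show that the change carries over unaltered, since each core offers only one pair and the gap between the steps could be scatter alone.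

The compounds shown leave open how pyridin-2-yl or a plain phenyl group on the same oxygen would compare with the two pyridinyl groups on either core. They also leave open whether the result would hold with an amine in place of the methoxy group, and whether a further core would follow either step.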